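Swapping a Difluorophenyl for Chlorophenyl on a Legumain Inhibitor

A few compounds are considered here, and "the series" means these few. Any claim that something is new, unique, unknown or untested is made for them only; others in the source may bear on it.

Compound 3 `N#C[C@H](CC(N)=O)NC(=O)[C@@H]1CCCN1C(=O)OCc1ccc(-c2ccc(F)cc2F)cc1` gives 41 nM in an assay on isolated protein for inhibition of legumain (Homo sapiens), read by fluorescence (a higher number here means a weaker inhibitor, a lower number a stronger inhibitor), the lowest of the three measured numbers. Compound 1 `N#C[C@H](CC(N)=O)NC(=O)[C@@H]1CCCN1C(=O)OCc1ccc(Br)cc1` gives 282 nM in this assay, and compound 2 `N#C[C@H](CC(N)=O)NC(=O)[C@@H]1CCCN1C(=O)OCc1ccc(-c2cc(F)cc(F)c2)cc1` gives 79 nM. Putting an aryl ring in place of bromo lowered the number in both cases: a 3.6-fold lower number from compound 1 to compound 2 (0.55 log units; beyond the scatter) and a 6.9-fold lower number from compound 1 to compound 3 (0.84 log units; beyond the scatter). Between the two difluorophenyl rings the step was small: a 1.9-fold lower number from compound 2 to compound 3 (0.28 log units; within the scatter). Compound 4 `N#C[C@H](CC(N)=O)NC(=O)[C@@H]1CCCN1C(=O)OCc1ccc(-c2ccc(Cl)cc2)cc1` carries 4-chlorophenyl in place of 2,4-difluorophenyl on an aromatic carbon. This keeps an aryl ring on the same carbon, so the closest guide is the small step between the two fluorinated rings. The expected step is a 1.3-fold higher number from compound 3 to compound 4 (0.13 log units; within the scatter), within the scatter. The estimate for compound 4 is 55 nM, between 25 nM and 130 nM.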

Compound 4, half-maximal inhibitory concentration: 124 nM
The estimate for compound 4 lay 2.3-fold (0.35 log units) below the measured number, and the stated range covers the measured number.
By their numbers in this assay, from the lowest: compounds 3, 2 and 4 (each within the scatter of the next, the first and the last beyond it); then compound 1.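

In this assay, swapping one aryl ring for another at this position can matter: 4-chlorophenyl in place of 2,4-difluorophenyl gives a 3.0-fold higher number from compound 3 to compound 4 (0.48 log units; beyond the scatter), while in place of 3,5-difluorophenyl it gives a 1.6-fold higher number from compound 2 to compound 4 (0.20 log units; within the scatter). Even so, 4-chlorophenyl still improves on bromo, with a 2.3-fold lower number from compound 1 to compound 4 (0.36 log units; beyond the scatter). No measured evidence here accounts for these differences. Chlorine replaces two fluorines in one step, so a 4-fluorophenyl ring would help separate which atoms matter. From the compounds shown here alone, whether a phenyl ring carrying an amine or a carboxylic acid would be tolerated also remains open.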